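Carbonyl substituent swap: ethoxy to cyclohexylamino

The source may hold more compounds than are shown below. What is called first, only, known or untested is meant among the compounds shown, and "the series" means these compounds.

Three compounds of a shared core have been run in a functional assay on HCT-116 cells (Homo sapiens) for cytotoxicity, read by MTT assay; a higher number here means a weaker inhibitor, a lower number a stronger inhibitor. Compound 1 `CCc1cc(S(=O)(=O)N2C[C@H](c3ccccc3)NC2=O)ccc1NC(=O)OC(C)C` gives 60 nM, compound 2 `CCOC(=O)Nc1ccc(S(=O)(=O)N2C[C@H](c3ccccc3)NC2=O)cc1C` gives 70 nM, and compound 3 `CCOC(=O)Nc1ccc(S(=O)(=O)N2C[C@H](c3ccccc3)NC2=O)cc1CC` gives 70 nM. On these numbers compound 3 is level with compound 2, the two together carrying the highest of the three values, while the step of a 1.2-fold higher number from compound 1 to compound 3 (0.07 log units; within the scatter) and the step of no change at the digits printed from compound 2 to compound 3 (within the scatter) both sit within the scatter, so all three compounds are effectively indistinguishable in this assay.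

Compound 4 `CCc1cc(S(=O)(=O)N2C[C@H](c3ccccc3)NC2=O)ccc1NC(=O)NC1CCCCC1` is compound 3 with a single change: cyclohexylamino in place of ethoxy on a carbonyl carbon. Going by the values given here, of the two measured steps, only the one that alters the group on that carbonyl carbon bears on this change, and it stayed within the scatter; the other step concerns a substituent on the aromatic ring and does not touch the carbonyl carbon at all. Among the compounds with values here, neither step replaces an oxygen-linked group with a nitrogen-linked one, so the series gives no direct precedent. On that basis a small step is expected for compound 4, as a 1.3-fold higher number from compound 3 to compound 4 (0.11 log units; within the scatter), with the direction open. Compound 4 is therefore estimated at 90 nM, with a range from 30 nM to 300 nM.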

Compound 4, half-maximal inhibitory concentration: 300 nM
Compound 4: middle estimate off by 3.3-fold (0.52 log units), on the low side, and the stated range covers the measured number.
By their numbers in this assay, from the lowest: compounds 1, 2 and 3 (each within the scatter of the next); then compound 4.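

In this assay, the carbonyl carbon turns out to be sensitive to what it carries: swapping ethoxy for cyclohexylamino gives a step beyond the scatter (a 4.3-fold higher number from compound 3 to compound 4 (0.63 log units; beyond the scatter)), and swapping isopropoxy for cyclohexylamino gives one of similar size (a 5.0-fold higher number from compound 1 to compound 4 (0.70 log units; beyond the scatter)). Ethoxy and isopropoxy had stayed within the scatter of each other at this place, so the tolerance seen there so far extends across those two oxygen-linked groups but not to cyclohexylamino, and the higher numbers mean weaker inhibition. The change brings in a nitrogen link, a six-membered ring of carbon and a hydrogen-bond donor all at once, so the step belongs to the swap as a whole and not to any one of these features.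

Nothing available accounts for the higher number at this place. Going by these compounds, whether the step follows the nitrogen link or the ring stays open, and an ethylamino group and a cyclohexyloxy group on the same carbonyl carbon would pull the two apart.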